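The compounds below may be only part of what the source reports. "The series", "measured", "known", "first", "only" and "open" are said of these compounds alone.

Of the compounds shown here, three on a shared core have been measured, and a fourth awaits its number. Compound 1 `NC(=O)c1c(NC(=O)c2ccccc2F)sc2c1CCN(C(=S)Nc1ccccc1Cl)C2` and compound 2 `NC(=O)c1c(NC(=O)c2ccccc2F)sc2c1CCN(C(=O)Nc1ccccc1Cl)C2` differ only by a group of 10 heavy atoms (7 carbon, 1 nitrogen, 1 oxygen, 1 chlorine; one six-membered aromatic ring of carbon only) in place of a group of 10 heavy atoms (7 carbon, 1 nitrogen, 1 sulfur, 1 chlorine; one six-membered aromatic ring of carbon only), on an amine nitrogen in a ring. In a functional assay on HL-60 cells (Homo sapiens) for antiproliferative activity, with a stated time of 24 h (on this read-out lower numbers stand for stronger inhibition and higher numbers for weaker inhibition), compound 1 gives 12500 nM, and compound 2 gives 32700 nM, a step of a 2.6-fold higher number from compound 1 to compound 2 (0.42 log units; beyond the scatter).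

The core of compound 3 `NC(=O)c1c(NC(=O)c2cccc([N+](=O)[O-])c2)sc2c1CCN(C(=S)Nc1ccccc1Cl)C2` departs from the core of compound 1 by 3-nitrophenyl in place of 2-fluorophenyl on a carbonyl carbon. In this assay compound 3 gives 7040 nM, which is a 1.8-fold lower number from compound 1 to compound 3 (0.25 log units; within the scatter).

Compound 4 `NC(=O)c1c(NC(=O)c2cccc([N+](=O)[O-])c2)sc2c1CCN(C(=O)Nc1ccccc1Cl)C2` is not yet measured. It stands to compound 3 as compound 2 stands to compound 1, by a group of 10 heavy atoms (7 carbon, 1 nitrogen, 1 oxygen, 1 chlorine; one six-membered aromatic ring of carbon only) in place of a group of 10 heavy atoms (7 carbon, 1 nitrogen, 1 sulfur, 1 chlorine; one six-membered aromatic ring of carbon only), on an amine nitrogen in a ring, at the same place on the same kind of ring. The expected step for compound 4 is a 2.6-fold higher number from compound 3 to compound 4 (0.41 log units; beyond the scatter), resting on the step of a 2.6-fold higher number from compound 1 to compound 2 (0.42 log units; beyond the scatter) already seen. In this assay compound 4 is estimated at 18000 nM, expected to fall between 9000 nM and 37000 nM.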

Compound 4, half-maximal inhibitory concentration: 18500 nM
For compound 4 the middle estimate is 1.0-fold (0.01 log units) below the measured one, within the range that was stated.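

In this assay, putting (2-chlorophenyl)carbamoyl in place of its sulfur-containing counterpart on the amine nitrogen gives a 2.6-fold higher number from compound 3 to compound 4 (0.42 log units; beyond the scatter), and this step carries from the core of compound 1 to the core of compound 3 with no gap between the two: the same change on two cores in this assay, a 2.6-fold higher number (0.42 log units; beyond the scatter) from compound 1 to compound 2 and a 2.6-fold higher number (0.42 log units; beyond the scatter) from compound 3 to compound 4, 1.0-fold (0.00 log units) apart, within the scatter of two such steps. The other change, 3-nitrophenyl in place of 2-fluorophenyl, gives a 1.8-fold lower number from compound 2 to compound 4 (0.25 log units; within the scatter), which also reads alike on both cores, though each of its steps stays within the scatter: the same change on two cores in this assay, a 1.8-fold lower number (0.25 log units; within the scatter) from compound 1 to compound 3 and a 1.8-fold lower number (0.25 log units; within the scatter) from compound 2 to compound 4, 1.0-fold (0.00 log units) apart, within the scatter of two such steps. This shows the two changes acting independently across these four compounds in this assay, but it shows nothing about other cores or other cells, and it does not explain the size of either step.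

The compounds shown leave open whether the same step holds with a pyridine ring or a longer chain on the carbonyl carbon. Going by these compounds, it is also open whether it holds with an unsubstituted phenyl or a methoxyphenyl in place of the 2-chlorophenyl.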